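A few compounds are considered here, and "the series" means these few. Any claim that something is new, unique, unknown or untested is made for them only; others in the source may bear on it.

compound 1 `O=C(NCc1cccc(Cl)c1Cl)c1c([N+](=O)[O-])noc1-c1ccc([N+](=O)[O-])cc1` gives "not determined" (no result reported)
compound 2 `O=C(NCc1cccc(Br)c1)c1c([N+](=O)[O-])noc1-c1ccc(Cl)cc1` gives "not determined" (no result reported)
compound 3 `COc1cccc(CNC(=O)c2c([N+](=O)[O-])noc2-c2ccc(Cl)cc2)c1` gives 68600 nM

In an ADME assay on J774.A1 cells (Mus musculus) for cytotoxicity, read by MTT assay, with a stated time of 48 h (on this read-out lower numbers stand for higher toxicity in this test and higher numbers for lower toxicity in this test), only compound 3 has a number, so it stands alone and cannot yet be ranked against the others. Compound 4 `O=C(NCc1cccc(Cl)c1Cl)c1c([N+](=O)[O-])noc1-c1ccc(Cl)cc1` keeps the shared core. The only difference is 2,3-dichlorophenyl in place of 3-methoxyphenyl on a saturated chain carbon bound to an amide-type nitrogen, which means 2,3-dichlorophenyl in place of 3-methoxyphenyl on a saturated chain carbon bound to an amide-type nitrogen. Within the data shown here, no measured step between compounds exists to guide the size of this change, and compound 3 at 68600 nM is the sole anchor. The expected result is a 1.7-fold lower number from compound 3 to compound 4 (0.23 log units; within the scatter), leaning slightly toward lower numbers but not beyond the usual scatter. For compound 4 the estimate is 40000 nM, with an expected range from 13000 nM to 100000 nM in this assay once it is tested.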

Compound 4, half-maximal cytotoxic concentration: 73700 nM
Compound 4: middle estimate off by 1.8-fold (0.27 log units), on the low side; measured number inside the range.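

The exchange of 3-methoxyphenyl for 2,3-dichlorophenyl at this position, on a saturated chain carbon bound to an amide-type nitrogen, comes to a 1.1-fold higher number from compound 3 to compound 4 (0.03 log units; within the scatter) in this assay. For this pair, then, the read-out does not separate the two groups, so this one exchange leaves cell toxicity in this test unchanged. Nothing measured here explains this result.

Going by these compounds, what an amine or a carboxylic acid at this position would give remains open. So does the effect of a longer chain there.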